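Amide-nitrogen substituent swap on the shared core

The source may hold more compounds than are shown below. What is called first, only, known or untested is meant among the compounds shown, and "the series" means these compounds.

Three compounds on the shared core have numbers in an assay for inhibition of 6-phosphofructo-2-kinase/fructose-2,6-bisphosphatase 3 (Homo sapiens), read by ADP-Glo, with a stated time of 2 h; a higher number here means a weaker inhibitor, a lower number a stronger inhibitor. Compound 1 `Cn1ccc2ccc(-c3cc(Nc4ccccc4S(=O)(=O)NCC4CCOCC4)cc4nccnc34)cc21` gives 26 nM. Compound 2 `Cn1ccc2ccc(-c3cc(Nc4cnccc4C(=O)NC4CCNC(=O)C4)cc4nccnc34)cc21` gives 69 nM. Compound 3 `CN1CC(NC(=O)c2ccncc2Nc2cc(-c3ccc4ccn(C)c4c3)c3nccnc3c2)CCC1=O` gives 116 nM, the highest of the three numbers: the step of a 1.7-fold higher number from compound 2 to compound 3 (0.23 log units; within the scatter) lies within the scatter, whereas the gap between compound 3 and compound 1 lies beyond it.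

Compound 4 `CC(=O)N1CCC(NC(=O)c2ccncc2Nc2cc(-c3ccc4ccn(C)c4c3)c3nccnc3c2)C1` is not yet measured in this assay. It differs from compound 3 by 1-acetylpyrrolidin-3-yl in place of 1-methyl-6-oxopiperidin-3-yl on an amide-type nitrogen. Going by the values given here, the only measured step at this position is a 1.7-fold higher number from compound 2 to compound 3 (0.23 log units; within the scatter), a change of the ring substituent on the same amide-type nitrogen that stayed within the scatter. Nothing else among the measured compounds touches this place. On that basis the expected step of a 1.1-fold lower number from compound 3 to compound 4 (0.02 log units; within the scatter) is none beyond the scatter, in no particular direction. Compound 4 is therefore estimated at 110 nM in this assay, with a range from 45 nM to 270 nM.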

Compound 4, half-maximal inhibitory concentration: 105 nM
Estimate against measurement, compound 4: 1.0-fold (0.02 log units) above; low and high end bracket the measured number.
By their numbers in this assay, from the lowest: compound 1; then compounds 2, 4 and 3 (each within the scatter of the next).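

In this assay, replacing 1-methyl-6-oxopiperidin-3-yl with 1-acetylpyrrolidin-3-yl on the amide-type nitrogen gives a 1.1-fold lower number from compound 3 to compound 4 (0.04 log units; within the scatter), and replacing 2-oxopiperidin-4-yl with the same group gives a 1.5-fold higher number from compound 2 to compound 4 (0.18 log units; within the scatter). Both steps lie within the scatter, so a five-membered ring can take the place of either six-membered ring here, with no change that these numbers can resolve, at least among these three substituents of similar make-up. No measurement available here offers an explanation for this flat result.

Going by these compounds, all three substituents carry a carbonyl, so it remains open whether this position stays as flat with a piperidin-4-yl bearing a free amine or with a group ending in a carboxylic acid. A longer chain between the amide-type nitrogen and the ring is likewise an open question.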